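The source may report more compounds than this note shows. Statements on the series, on what has been measured and on what is new or still open speak of the compounds shown alone.

Measured compounds:
- compound 1 `Cc1nnc(SCc2cc(=O)c3cc(Cl)ccc3o2)o1`; in a functional assay on MCF7 cells (Homo sapiens) for cytotoxicity, read by MTT assay, with a stated time of 72 h (on this read-out higher numbers stand for weaker inhibition and lower numbers for stronger inhibition), compound 1 reaches only the assay limit > 25000 nM.
- compound 2 `Cc1ccc2oc(CSc3nnc(C)s3)cc(=O)c2c1`; in this assay compound 2 likewise reaches only the assay limit > 25000 nM.

Compound 2 therefore stands at the limit of this assay, and it shares that standing with compound 1, as the limit of > 25000 nM in this assay, at which 2 of the 2 values shown sit, records; no number is known for either compound, only that each lies past the limit. The step to compound 3 `Cc1nnc(SCc2cc(=O)c3cc(Cl)ccc3o2)s1` is chloro in place of methyl on an aromatic carbon. Going by the values given here, no measured step between two compounds with real numbers exists here, so the size of this change in this assay cannot be read from any precedent. Because compound 2 sits at the limit > 25000 nM, compound 3 is expected to remain there too, with a step that the limit leaves unreadable from compound 2 to compound 3 that amounts to nothing beyond the scatter. Compound 3 is estimated at 35000 nM, between 10000 nM and 120000 nM, and is most likely to be reported once more only as a limit.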

Compound 3, half-maximal inhibitory concentration: > 25000 nM
Compound 3: a limit, no number; the forecaster's own chance of this, stated with the estimate: 75%; the middle value is on the limit's open side.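

Going by these compounds alone, no step from compound 1 or compound 2 to compound 3 can be read in this assay, as all three stand at one limit: the limit of > 25000 nM in this assay, at which 3 of the 3 values shown sit. The compounds shown leave open how far each lies past that limit, and so whether chloro in place of methyl changes the read-out at all.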